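Diaryl urea series: chloro for trifluoromethyl

The source may hold more compounds than are shown below. What is called first, only, known or untested is meant among the compounds shown, and "the series" means these compounds.

Measured compounds, in a functional assay on SK-OV-3 cells (Homo sapiens) for inhibition, read by sulforhodamine B assay, with a stated time of 48 h, tested at 10 uM; on this read-out lower numbers stand for a stronger effect and higher numbers for a weaker effect at the one concentration tested:
compound 1 `COc1cc2cc(Oc3ccc(NC(=O)Nc4ccc(C(F)(F)F)cc4)cc3)c(C)nc2cc1OC` gives 38.8%
compound 2 `COc1cc2cc(Oc3ccc(NC(=O)Nc4ccc(Cl)c(C(F)(F)F)c4)cc3)c(C)nc2cc1OC` gives -4.09%

Among the compounds with values here, compound 2 stands lowest of the two numbers; the only other value is that of compound 1. Within the data shown here, the single measured step is a number 42.9 percentage points lower from compound 1 to compound 2 (beyond the scatter), a large drop on changing the aryl on the urea. Compound 3 `COc1cc2cc(Oc3ccc(NC(=O)Nc4ccc(Cl)c(Cl)c4)cc3)c(C)nc2cc1OC` differs from compound 2 by chloro in place of trifluoromethyl on an aromatic carbon, so the aryl reads 3,4-dichlorophenyl in place of 4-chloro-3-(trifluoromethyl)phenyl. Among the measured compounds shown here, no measured step exchanges these two groups, so the only step bears indirectly, showing this ring is sensitive. A modest loss is expected, a number 10.1 percentage points higher from compound 2 to compound 3 (beyond the scatter), in this assay. For compound 3 the estimate is 6%, range -15% to 32%.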

Compound 3, a percentage reported as activity, at one concentration (the size of the read-out at that concentration, not a potency): 28.6%
For compound 3 the middle estimate is 22.6 percentage points below the measured one; low and high end bracket the measured number.
By their numbers in this assay, from the lowest: compound 2; then compound 3; then compound 1.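

In this assay, this aromatic carbon proves to be more than a place for any halogen-sized group: chloro in place of trifluoromethyl gives a number 32.7 percentage points higher from compound 2 to compound 3 (beyond the scatter). The 3,4-dichlorophenyl urea still retains part of the gain over the 4-(trifluoromethyl)phenyl urea, with a number 10.2 percentage points lower from compound 1 to compound 3 (beyond the scatter), so the two aryl changes are not equivalent. Nothing available explains this difference.

Open, from the compounds shown here alone, is whether a methyl, a methoxy or a nitrile on this carbon would read nearer to compound 2 or to compound 3.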